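The source may report more compounds than this note shows. Statements on the series, on what has been measured and on what is new or still open speak of the compounds shown alone.

Measured so far:
- Compound 1, `C=CCn1c(=O)/c(=C\c2cccc(Cl)c2)[nH]c(=O)/c1=C\c1ccccc1OC`: 1200 nM
- Compound 2, `C=CCn1c(=O)/c(=C\c2cccc(Cl)c2Cl)[nH]c(=O)/c1=C\c1ccccc1OC`: 500 nM

Both numbers come from a functional assay on U-937 cells (Homo sapiens) for cytotoxicity, read by CCK-8 assay, with a stated time of 72 h; a higher number here means a weaker inhibitor, a lower number a stronger inhibitor. Among the measured compounds shown here, compound 2 stands at the lowest of the two numbers; its nearest neighbour is compound 1, and the single step between them, a 2.4-fold lower number from compound 1 to compound 2 (0.38 log units; beyond the scatter), is modest but beyond the scatter. Compound 3, `C=CCn1c(=O)/c(=C\c2cccc(Br)c2)[nH]c(=O)/c1=C\c1ccccc1OC`, has not yet been measured. It differs from compound 2 by 3-bromophenyl in place of 2,3-dichlorophenyl on a double-bonded chain carbon bound to an aromatic carbon. This change has two parts: the chloro that compound 2 carries beyond compound 1 is removed again, and the remaining chlorine is replaced by bromine. For the measured compounds named here, only the first part is covered by a measured step, namely the one from compound 1 to compound 2, which would be undone; reversing it points to a higher number of about the same modest size. Going by the values given here, no measured step covers a swap of chlorine for bromine, so nothing can be said of that part. Compound 3 is therefore expected to land near compound 1, with the step of a 2.0-fold higher number from compound 2 to compound 3 (0.30 log units; within the scatter) expected. The estimate for compound 3 is 1000 nM, within a range from 400 nM to 2500 nM.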

Compound 3, half-maximal inhibitory concentration: 1100 nM
For compound 3 the middle estimate is 1.1-fold (0.04 log units) below the measured one; the measured number falls inside the stated range.
By their numbers in this assay, from the lowest: compound 2; then compounds 3 and 1 (each within the scatter of the next).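

In this assay, among the compounds shown here, bromo in place of chloro on the aromatic carbon gives a 1.1-fold lower number from compound 1 to compound 3 (0.04 log units; within the scatter) and so no readable change, which means these two halogens cannot be told apart here when each is the only one on that ring. The larger change gives a 2.2-fold higher number from compound 2 to compound 3 (0.34 log units; beyond the scatter) and is modest but beyond the scatter; since compound 3 sits with compound 1, what sets compound 2 apart among these three is the added chlorine of its 2,3-dichlorophenyl group, not which single halogen the ring carries. Nothing available here explains why the added chlorine registers while the swap of halogen does not.

From the compounds shown here alone, it remains open whether a 2,3-dibromophenyl group would give the same modest gain as the 2,3-dichlorophenyl group, so the effect of a second halogen is so far seen with chlorine alone. Going by these compounds, it is also open how groups that are not halogens, such as a methyl, a nitrile or an amine, would read on this ring in the same cell assay.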